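Replacing the hydroxymethyl group with dimethylamino

This account rests on a few compounds, and the source may have more. Where it says the series, first, only, none or still open, it means among the compounds named here.

Measured so far in an assay on LM cells for displacement of a labelled ligand from Neuropeptide Y receptor type 5 (Homo sapiens); a higher number here means a weaker inhibitor, a lower number a stronger inhibitor:
compound 1 `N#Cc1cccc(C2=NC(c3ccc(F)cc3)(c3ccc(F)cc3)CN2)c1` gives 2.7 nM
compound 2 `OCc1cccc(C2=NC(c3ccc(F)cc3)(c3ccc(F)cc3)CN2)c1` gives 59 nM

Of these two numbers, compound 2 has the highest, so it is the weaker binder of the pair. Among the compounds with values here, the one measured step is a 22-fold higher number from compound 1 to compound 2 (1.34 log units; beyond the scatter), a large change that shows how much the group at this position can move the result.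

Compound 3 `CN(C)c1cccc(C2=NC(c3ccc(F)cc3)(c3ccc(F)cc3)CN2)c1` has not been measured. It differs from compound 2 in one place: dimethylamino in place of hydroxymethyl on an aromatic carbon, on an aromatic carbon meta to a large group. Within the data shown here, no measured step carries this same exchange, so the only guide is that the position is sensitive. Dimethylamino keeps one hydrogen-bond acceptor but has no donor; whether this brings the number back toward compound 1 or leaves it near compound 2 cannot be read from the data. Compound 3 is therefore expected to show a modest improvement, a 2.0-fold lower number from compound 2 to compound 3 (0.29 log units; within the scatter), with a wide range. The estimate for compound 3 in this assay is 30 nM, between 6 nM and 150 nM.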

Compound 3, half-maximal inhibitory concentration: > 1000 nM
Compound 3 ended at the assay's limit (the forecaster's own chance of this, stated with the estimate: 3%); at least 33-fold (1.52 log units) between middle value and limit.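

In this assay compound 3 sits at a limit of the assay, so its entry is not an exact number: the limit of > 1000 nM in this assay, at which 1 of the 3 values shown sits.

Exchanging hydroxymethyl for dimethylamino gives an at least 16-fold higher number from compound 2 to compound 3 (1.22 log units; beyond the scatter), and exchanging cyano for dimethylamino gives an at least 370-fold higher number from compound 1 to compound 3 (2.56 log units; beyond the scatter), so the loss seen with compound 2 was not the worst this position allows. Hydroxymethyl and dimethylamino each count as a hydrogen-bond acceptor, so having an acceptor at this position is not enough to keep binding.

The compounds shown cannot separate the lost hydrogen-bond donor from the larger group as the source of the drop, and a plain amine or a methoxy group would be needed to tell these apart. From the compounds shown here alone, how far past the limit compound 3 really lies also remains unknown.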